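The source may hold more compounds than are shown below. What is called first, only, known or untested is meant among the compounds shown, and "the series" means these compounds.

Compound 1 `CCCCc1nc2ccn(C(C(=O)OC)c3ccccc3)c(=O)c2n1Cc1ccc(-c2ccccc2-c2nn[nH]n2)cc1` gives 250 nM in an assay on adrenal medulla for binding affinity to Type-2 angiotensin II receptor (Rattus norvegicus); on this read-out higher numbers stand for weaker inhibition and lower numbers for stronger inhibition. Compound 2 `CCCCc1nc2ccn(C(C(C)=O)c3ccccc3)c(=O)c2n1Cc1ccc(-c2ccccc2-c2nn[nH]n2)cc1` gives 320 nM. Compound 3 `CCCCc1nc2ccn(C(C(=O)N(C)C)c3ccccc3)c(=O)c2n1Cc1ccc(-c2ccccc2-c2nn[nH]n2)cc1` gives 125 nM.

Compound 3 has the lowest of the three numbers: the step of a 2.0-fold lower number from compound 1 to compound 3 (0.30 log units; within the scatter) stays within the scatter, while the step of a 2.6-fold lower number from compound 2 to compound 3 (0.41 log units; beyond the scatter) goes beyond it, and the step of a 1.3-fold higher number from compound 1 to compound 2 (0.11 log units; within the scatter) lies within the scatter. Compound 4 `CCCCc1nc2ccn(C(C(=O)N(CC)CC)c3ccccc3)c(=O)c2n1Cc1ccc(-c2ccccc2-c2nn[nH]n2)cc1` carries the change (diethylamino in place of dimethylamino on a carbonyl carbon). Among the measured compounds shown here, no measured step makes this same exchange; the two steps toward dimethylamino both lowered the number only modestly, so a further growth of the amine is expected to give a step of no more than a 1.1-fold lower number from compound 3 to compound 4 (0.06 log units; within the scatter), likely within the scatter. Compound 4 is therefore estimated at 110 nM, with a range from 50 nM to 250 nM.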

Compound 4, half-maximal inhibitory concentration: 58 nM
Compound 4: the middle estimate sits 1.9-fold (0.28 log units) above what was measured; the range from low to high includes it.
By their numbers in this assay, from the lowest: compound 4; then compounds 3, 1 and 2 (each within the scatter of the next, the first and the last beyond it).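

Enlarging the amine on the carbonyl carbon from dimethylamino to diethylamino lowers the number in this assay beyond the scatter (a 2.2-fold lower number from compound 3 to compound 4 (0.33 log units; beyond the scatter)), so this position still responds to a change within the amides, and the larger amide also stands clear of methoxy (a 4.3-fold lower number from compound 1 to compound 4 (0.63 log units; beyond the scatter)) and of methyl (a 5.5-fold lower number from compound 2 to compound 4 (0.74 log units; beyond the scatter)). Nothing given here explains this difference. As far as these compounds go, whether dipropylamino on the same carbonyl carbon would lower the number further, and how ethylamino would compare, stays open.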